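Anilide series: trifluoromethyl to fluoro on the cinnamoyl ring

The source may report more compounds than this note shows. Statements on the series, on what has been measured and on what is new or still open speak of the compounds shown alone.

Measured so far in a functional assay on MDA-MB-231 cells (Homo sapiens) for inhibition, read by MTT assay, with a stated time of 48 h; a higher number here means a weaker inhibitor, a lower number a stronger inhibitor:
compound 1, `COc1cc(/C=C/c2ccc(NC(=O)/C=C/c3cc(OC)c(O)c(OC)c3)cc2)cc(OC)c1`: 7130 nM
compound 2, `COc1cc(/C=C/c2ccc(NC(=O)/C=C/c3ccc(C(F)(F)F)cc3)cc2)cc(OC)c1`: 3520 nM

For the measured compounds named here, compound 2 holds the lowest of the two numbers in this assay; the only other number is that of compound 1, the step being a 2.0-fold lower number from compound 1 to compound 2 (0.31 log units; beyond the scatter). Compound 3 `COc1cc(/C=C/c2ccc(NC(=O)/C=C/c3ccc(F)cc3)cc2)cc(OC)c1` keeps the shared core of compound 2 and differs from it by fluoro in place of trifluoromethyl on an aromatic carbon.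

Going by the values given here, the single measured step exchanges the whole aryl group on the double-bonded chain carbon, so no measured pair isolates the trifluoromethyl-to-fluoro exchange itself, and no step among the two numbers gives a direction for it. With nothing in the data pointing either way, the step in this assay from compound 2 to compound 3 is expected to be small, likely within the scatter, a 1.3-fold higher number from compound 2 to compound 3 (0.11 log units; within the scatter). Compound 3 is accordingly estimated at 4500 nM, within 2000 nM to 10000 nM.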

Compound 3, half-maximal inhibitory concentration: 9390 nM
Beside the measured number, compound 3's estimate is 2.1-fold (0.32 log units) below it; low and high end bracket the measured number.
By their numbers in this assay, from the lowest: compound 2; then compounds 1 and 3 (each within the scatter of the next).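

In this assay the exchange at this aromatic carbon, para to a large group, can now be read on its own: fluoro in place of trifluoromethyl gives a 2.7-fold higher number from compound 2 to compound 3 (0.43 log units; beyond the scatter) and so trifluoromethyl is the better of these two groups at this position. Exchanging the whole aryl group gives a 1.3-fold higher number from compound 1 to compound 3 (0.12 log units; within the scatter) and so 4-fluorophenyl and 4-hydroxy-3,5-dimethoxyphenyl are not separated here, while 4-(trifluoromethyl)phenyl stands apart from both, though only modestly. No measurement at hand explains why the two groups differ at this position.

Still open, on these data alone, is whether the advantage is specific to trifluoromethyl or extends to other groups at this carbon, such as a nitrile, a chlorine or a methoxy group. An unsubstituted phenyl ring would show whether fluoro and trifluoromethyl each add to or take from the value of the bare ring.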